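The compounds below may be only part of what the source reports. "The series", "measured", "known", "first", "only" and "open" are said of these compounds alone.

Measured so far in a functional assay; on this read-out higher numbers stand for weaker inhibition and lower numbers for stronger inhibition:
- compound 1 `CC(C)=CCOc1ccc2c(c1)OC(c1ccc(Cl)cc1)CC2=O` gives 6970 nM
- compound 2 `CC(C)=CCOc1ccc2c(c1)OC(c1cccc(Br)c1)CC2=O` gives 5280 nM
- compound 3 `CC(C)=CCOc1cc(O)c2c(c1)OC(c1ccc(Cl)cc1)CC2=O` gives 7020 nM

Compound 3 stands within the scatter of compounds 1 and 2. For the measured compounds named here, compound 4 `CC(C)=CCOc1cc(O)c2c(c1)OC(c1ccc(C)cc1C)CC2=O` has 2,4-dimethylphenyl in place of 4-chlorophenyl on a saturated ring carbon as its only change. The closest measured change at that place, 3-bromophenyl in place of 4-chlorophenyl, gave a 1.3-fold lower number from compound 1 to compound 2 (0.12 log units; within the scatter) and is the main guide. The hydroxy change elsewhere gave a 1.0-fold higher number from compound 1 to compound 3 (0.00 log units; within the scatter) and bears only indirectly. Going by the values given here, no measured compound carries 2,4-dimethylphenyl, so the range stays wide. In this assay no step beyond the scatter is expected, with a 1.2-fold lower number from compound 3 to compound 4 (0.07 log units; within the scatter) as the estimated figure. Compound 4 is expected at 6000 nM with an estimated range of 2500 nM to 14000 nM for now.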

Compound 4, half-maximal inhibitory concentration: 6380 nM
Beside the measured number, compound 4's estimate is 1.1-fold (0.03 log units) below it; low and high end bracket the measured number.
By their numbers in this assay, from the lowest: compounds 2, 4, 1 and 3 (each within the scatter of the next).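

On the hydroxy-bearing core, in this assay, 2,4-dimethylphenyl in place of 4-chlorophenyl on the saturated ring carbon next to the ring oxygen gives a 1.1-fold lower number from compound 3 to compound 4 (0.04 log units; within the scatter). The earlier aryl change at this place, a 1.3-fold lower number from compound 1 to compound 2 (0.12 log units; within the scatter), lacked the hydroxy, so a flat result at this place now holds on both cores, for a halogen-free aryl group too. No evidence at hand bears on the reason for this flatness.

Only halogen- and methyl-substituted phenyl groups appear at this place. Going by these compounds, whether a carboxylic acid or an amine on that phenyl, or a longer chain replacing it, would give a step beyond the scatter stays open.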